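The compounds below may be only part of what the source reports. "The series", "measured", "known", "first", "only" and "open" are said of these compounds alone.

Measured compounds:
compound 1, `COc1cccc(-c2nc3ccc(C)cc3c(=O)[nH]2)c1`, gives > 50000 nM in a functional assay on HeLa cells (Homo sapiens) for cytotoxicity, read by MTT assay, with a stated time of 2 days (a lower number here means a stronger inhibitor, a higher number a weaker inhibitor), which is a limit of the assay and not a number
compound 2, `Cc1ccc2nc(-c3cccc(OC(F)(F)F)c3)[nH]c(=O)c2c1`, gives > 50000 nM in this assay, again a limit and not a number
compound 3, `COc1cccc(-c2nc3cc(C)ccc3c(=O)[nH]2)c1`, gives 8940 nM in this assay

Compound 1 and compound 2 differ in one place: trifluoromethyl in place of methyl on an oxygen on an aromatic ring. Both values are limits, so the step that the two limits leave unreadable from compound 1 to compound 2 cannot be read; this rests on (the limit of > 50000 nM in this assay, at which 2 of the 3 values shown sit).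

Compound 3 has the same atoms as compound 1, joined differently; the difference between the two cores is not broken down here. Compound 3 is the only one of the three that gives a number in this assay.

Compound 4, `Cc1ccc2c(=O)[nH]c(-c3cccc(OC(F)(F)F)c3)nc2c1`, has not been measured. It differs from compound 3 in the same way that compound 2 differs from compound 1: trifluoromethyl in place of methyl on an oxygen on an aromatic ring. The place around the change is the same in both pairs, so this is the same change. For the measured compounds named here, the only earlier example of it is unreadable, and the starting point, compound 3, already sits close to the limit in this assay.

The step from compound 3 to compound 4 in this assay is therefore expected to be small, a 1.7-fold higher number from compound 3 to compound 4 (0.22 log units; within the scatter), with a real chance that compound 4 returns only a limit. Compound 4 is estimated at 15000 nM, most likely between 4000 nM and 60000 nM.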

Compound 4, half-maximal inhibitory concentration: > 50000 nM
Compound 4 gave a limit, no number; the forecaster's own chance of this, stated with the estimate: 50%; middle value at least 3.3-fold (0.52 log units) away from the limit.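

Placing trifluoromethoxy where compound 3 carries methoxy gives an at least 5.5-fold higher number from compound 3 to compound 4 (0.74 log units; beyond the scatter) in this assay, so on the core of compound 3 this change clearly goes with weaker activity against the cells. Compound 4 gives > 50000 nM, which is a limit of the assay and not a number, so the step has a known smallest size but no known true size. The same change on the core of compound 1 cannot be read, so this single pair does not show whether the change behaves alike on both cores, and the limit of the assay stands in the way of any such comparison: the limit of > 50000 nM in this assay, at which 3 of the 4 values shown sit.

The compounds shown carry only methoxy or trifluoromethoxy at this place on the aromatic ring, which leaves open what a different group there, such as an amine, a carboxylic acid or a longer chain, would do in this assay. Since compound 3 is the only one of the four that gives a number, they also leave open whether any change at this place on its core could lower that number rather than raise it.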